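The source may hold more compounds than are shown below. What is called first, only, known or untested is meant among the compounds shown, and "the series" means these compounds.

Compound 1 `O=S(=O)(Nc1ccccc1)c1ccc(Br)cc1` gives 30000 nM
Compound 2 `CC(C)(C)c1ccc(S(=O)(=O)Nc2cccc(O)c2)cc1` gives 12000 nM

These two numbers come from a functional assay on A549 cells (Homo sapiens) for inhibition; a lower number here means a stronger inhibitor of growth, a higher number a weaker inhibitor of growth. Compound 2, at 12000 nM, has the lower number of the pair, and the gap to compound 1, at 30000 nM, lies beyond the usual scatter. Compound 3 `Cc1ccc(NS(=O)(=O)c2ccc(C(C)(C)C)cc2)cc1` has not yet been measured. It differs from compound 2 by carrying 4-methylphenyl in place of 3-hydroxyphenyl on a sulfonamide nitrogen and keeps the rest of the structure. Within the data shown here, no measured pair shows what this swap does in this assay, so the expectation is cautious: a small move toward a weaker inhibitor of growth, probably not beyond the scatter. The expected change is a 1.3-fold higher number from compound 2 to compound 3 (0.10 log units; within the scatter) in size. The estimate for compound 3 is 15000 nM, with an expected range from 6000 nM to 40000 nM.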

Compound 3, concentration for 50% growth inhibition: 11000 nM
The estimate for compound 3 lay 1.4-fold (0.13 log units) above the measured number; the measured number falls inside the stated range.
By their numbers in this assay, from the lowest: compounds 3 and 2 (each within the scatter of the next); then compound 1.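

Putting 4-methylphenyl in place of 3-hydroxyphenyl on a sulfonamide nitrogen gives in this assay a 1.1-fold lower number from compound 2 to compound 3 (0.04 log units; within the scatter) and so leaves the two compounds indistinguishable in this read-out. Among these compounds, this is the first direct view of this position: with the rest of the structure held constant, the hydroxyl group of compound 2 proves unnecessary for the growth inhibition seen here, and a methyl-bearing ring serves equally well in this single pair. No separate measurement bears on what lies behind this result.

On these data alone, whether this position tolerates change more widely remains open, since only these two rings can be compared directly. An amine, a carboxylic acid or a longer alkyl chain on the ring could still shift the number well beyond the scatter, in either direction.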